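A few compounds are considered here, and "the series" means these few. Any claim that something is new, unique, unknown or untested is made for them only; others in the source may bear on it.

In a functional assay on OE21 cells (Homo sapiens) for cytotoxicity, read by MTT assay, with a stated time of 72 h (on this read-out higher numbers stand for weaker inhibition and lower numbers for stronger inhibition), compound 1 `COc1cc(/C=C/C=O)cc(OC)c1OC/C=C(\C)CCC=C(C)C` gives 27000 nM and compound 2 `CC(C)=CCOc1ccc(C(=O)/C=C/c2ccccc2)c(O)c1` gives 39000 nM. These two values lie within the usual scatter of each other, so they cannot be ranked. For compound 3 `C=C(C)CCOc1c(OC)cc(/C=C/CO)cc1OC`, the result is a limit of the assay, > 100000 nM, and not a number. Compound 4 `CC(C)=CCOc1ccc(C(=O)/C=C/c2ccc(O)cc2)c(O)c1` has not yet been measured. It differs from compound 2 by a single change, (hydroxy in place of hydrogen on an aromatic carbon), with hydroxy in place of hydrogen on an aromatic carbon, so that phenyl becomes 4-hydroxyphenyl. Among the compounds with values here, no measured pair shows this change, so only a small shift toward stronger inhibition is expected in this assay, close to the scatter. The estimate amounts to a 1.6-fold lower number from compound 2 to compound 4 (0.19 log units; within the scatter). The expected value for compound 4 is 25000 nM, within an estimated range of 9000 nM to 60000 nM.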

Compound 4, half-maximal inhibitory concentration: 58000 nM
For compound 4 the middle estimate is 2.3-fold (0.37 log units) below the measured one, and the stated range covers the measured number.
By their numbers in this assay, from the lowest: compounds 1, 2 and 4 (each within the scatter of the next, the first and the last beyond it). At a limit, above all of these: compound 3.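

Within the data shown here, this is the first readable step for this change at this position: in this assay, hydroxy in place of hydrogen, turning phenyl into 4-hydroxyphenyl, gives a 1.5-fold higher number from compound 2 to compound 4 (0.17 log units; within the scatter). On this evidence, the added hydroxy cannot be told apart from no effect. Compound 4 still gives a number and not a limit, and only compound 3 sits at a limit: the limit of > 100000 nM in this assay, at which 1 of the 4 values shown sits.

Going by these compounds, whether an amine or a carboxylic acid at this place would stand apart from compound 2 stays open. So does whether the same change reads alike on the core of compound 1.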